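Series notes: compound 4, ethoxymethylene imine replacing aminoethylamine

The compounds below may be only part of what the source reports. "The series", "measured", "known", "first", "only" and "open" are said of these compounds alone.

Three compounds of the shared core have numbers in a functional assay on the whole organism (strain albino) for inhibition, with Rattus norvegicus as the target, read by paw edema, with a stated time of 1 h, at a dose of 0.029 mmol/kg by the oral route; a higher number here means more inhibition at the dose given (going by the name of the read-out), a lower number less inhibition. Compound 1 `CC/N=c1/c(C#N)c2n(c(=O)n1-c1ccccc1)CCC2` gives 7.82%. Among the compounds with values here, compound 2 `N#Cc1c2n(c(=O)n(-c3ccccc3)/c1=N\CCO)CCC2` gives 5.6%; the only single-point step measured, a number 2.2 percentage points lower from compound 1 to compound 2 (within the scatter), shows that a hydroxy added two bonds along the chain from the double-bonded nitrogen leaves the read-out essentially where it was. Compound 3 `N#CC1=C(NCCN)N(c2ccccc2)C(=O)N2CCCC12` gives 15.7%, the highest of the three numbers: compound 1 lies within the scatter of it, compound 2 lies beyond the scatter below it.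

Compound 4 `CCO/C=N/C1=C(C#N)C2CCCN2C(=O)N1c1ccccc1` differs from compound 3 in one place: a group of 5 heavy atoms (3 carbon, 1 nitrogen, 1 oxygen; no ring) in place of a group of 4 heavy atoms (2 carbon, 2 nitrogen; no ring), on a double-bonded ring carbon. Within the data shown here, no measured step covers this exchange; the step from compound 1 to compound 2 concerns a hydroxy on a chain, not the replacement of an aminoethylamino group by an imine bearing an ethoxy. All that the numbers show is that the two compounds carrying a double-bonded nitrogen at this position, compound 1 and compound 2, sit low and close together, while compound 3 sits somewhat higher. Compound 4 again carries a double-bonded nitrogen there, so a number near compound 1 is expected, a step of a number 6.7 percentage points lower from compound 3 to compound 4 (within the scatter) that is not expected to exceed the scatter. Compound 4 is estimated at 9%, in the range 0% to 20%.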

Compound 4, a percentage reported as inhibition, in the whole organism at one dose (the size of the read-out at that dose, not a potency): 22.5%
Estimate against measurement, compound 4: 13.5 percentage points below; measured number above the stated range.
By their numbers in this assay, from the lowest: compounds 2, 1, 3 and 4 (each within the scatter of the next, the first and the last beyond it).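

In this assay, the exchange on the double-bonded ring carbon gives a number 6.8 percentage points higher from compound 3 to compound 4 (within the scatter), the first step read at this position itself, as the earlier step concerned only a hydroxy on a saturated chain. The group that leaves has 2 hydrogen-bond donors and the group that enters has 0, with 2 hydrogen-bond acceptors on each side, so for this pair the read-out at the one dose does not need those donors on this carbon. No supporting measurement bears on why the read-out holds across this exchange.

From the compounds shown here alone, whether a plain amine, a carboxylic acid or a longer alkyl chain on the same ring carbon would shift the number in this assay beyond the scatter from compound 3 stays open. Also open, going by these compounds, are which part of the entering group, the ethoxy or the imine, accounts for the reading in compound 4, and how these single-dose readings would translate into potency.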